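A few compounds are considered here, and "the series" means these few. Any claim that something is new, unique, unknown or untested is made for them only; others in the source may bear on it.

Compound 1 `O=C(CN(C(=O)C1CCOCC1)C1CCCCC1)Nc1cc(F)cc(F)c1`: 3
Compound 2 `O=C(CN(C(=O)c1ccc(-n2ccnc2)cc1)C1CCCCC1)Nc1cc(F)cc(F)c1`: 2.7

In a physicochemical assay for lipophilicity (on this read-out lower numbers stand for lower lipophilicity and higher numbers for higher lipophilicity), compound 1 gives 3 and compound 2 gives 2.7. These two numbers lie within the usual scatter of each other, so compound 2 cannot be ranked against compound 1 on this evidence. The next compound to be measured is compound 3 `O=C(CN(C(=O)c1ccc(N2CCCC2)cc1)C1CCCCC1)Nc1cc(F)cc(F)c1`. It keeps the rest of compound 2 and alters a single group, with pyrrolidin-1-yl in place of 1H-imidazol-1-yl on an aromatic carbon, para to a large group (pyrrolidin-1-yl in place of 1H-imidazol-1-yl on an aromatic carbon). Within the data shown here, no measured pair here shows this swap, so there is no observed step to borrow, and the size of the move remains a judgement. Starting from compound 2 at 2.7, and with a non-aromatic ring entering for an aromatic one, an upward step beyond the scatter is expected in this assay. The expected size of the move is a number 1.40 log units higher from compound 2 to compound 3 (beyond the scatter). The estimate for compound 3 is 4.1, with an expected range from 3.6 to 4.6.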

Compound 3, distribution coefficient: 4.5
Compound 3: the middle estimate sits 0.40 log units below what was measured, and the stated range covers the measured number.
By their numbers in this assay, from the lowest: compounds 2 and 1 (each within the scatter of the next); then compound 3.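

In this assay the aromatic carbon para to a large group proves to be a place where one swap can move the number a long way: pyrrolidin-1-yl in place of 1H-imidazol-1-yl gives a number 1.80 log units higher from compound 2 to compound 3 (beyond the scatter), a large step. The earlier compounds shown here offered no step of this kind, and this one comes with no change in the number of heavy atoms, only a carbon in place of a ring nitrogen and a non-aromatic ring in place of an aromatic one. Nothing available accounts for the size of the step, so it stands as an observation about this single pair.

With both changes arriving together, the compounds shown cannot tell whether the step follows the loss of the aromatic ring or the loss of the second ring nitrogen. A 1H-pyrrol-1-yl group, an aromatic five-membered ring with a single nitrogen, would pull those two changes apart at this place, while a morpholin-4-yl group would show how a second hetero atom reads in a non-aromatic ring.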